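The source may hold more compounds than are shown below. What is called first, only, known or untested is meant among the compounds shown, and "the series" means these compounds.

Three compounds share one core and differ only in the ring attached to a nitrogen on that core. Compound 1 `FC(F)(F)c1ccc(Nc2ncnc3sc(Nc4ccccc4Cl)nc23)cc1` carries a chloro on that ring, and in a functional assay on HEK293 cells for antagonist activity at transient receptor potential cation channel subfamily V member 1 (Rattus norvegicus), read by calcium flux (a lower number here means a stronger inhibitor, a higher number a weaker inhibitor), compound 1 gives 32 nM. Compound 2 `CSc1ccccc1Nc1nc2c(Nc3ccc(C(F)(F)F)cc3)ncnc2s1` carries methylsulfanyl there instead, and in this assay compound 2 gives 26 nM; the step is a 1.2-fold lower number from compound 1 to compound 2 (0.09 log units; within the scatter). Compound 3 `CS(=O)(=O)c1ccccc1Nc1nc2c(Nc3ccc(C(F)(F)F)cc3)ncnc2s1` carries methylsulfonyl, and in this assay compound 3 gives 221 nM, the highest number of the three: a 6.9-fold higher number from compound 1 to compound 3 (0.84 log units; beyond the scatter), and an 8.5-fold higher number from compound 2 to compound 3 (0.93 log units; beyond the scatter).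

Compound 4 `N#Cc1cc(Cl)c(Nc2nc3c(Nc4ccc(C(F)(F)F)cc4)ncnc3s2)c(Cl)c1` exchanges the whole attached ring: 2,6-dichloro-4-cyanophenyl in place of 2-(methylsulfonyl)phenyl on a nitrogen on an aromatic ring. The measured step that bears on this is the one from chloro to methylsulfonyl, which raised the number beyond the scatter; compound 4 returns to chloro, now twice, and adds a nitrile, about which nothing measured here speaks. The expectation is therefore a step back toward the number of compound 1, so compound 4 is expected to show a 4.9-fold lower number from compound 3 to compound 4 (0.69 log units; beyond the scatter). The estimate for compound 4 in this assay is 45 nM, expected to fall between 12 nM and 180 nM.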

Compound 4, half-maximal inhibitory concentration: 53 nM
Beside the measured number, compound 4's estimate is 1.2-fold (0.07 log units) below it; measured number inside the range.
By their numbers in this assay, from the lowest: compounds 2, 1 and 4 (each within the scatter of the next, the first and the last beyond it); then compound 3.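

The ring on this nitrogen can be exchanged whole, and the entering 2,6-dichloro-4-cyanophenyl and the leaving 2-(methylsulfonyl)phenyl have the same heavy-atom count, yet a 4.2-fold lower number from compound 3 to compound 4 (0.62 log units; beyond the scatter) in this assay, so that count alone does not set the number here. Two chloro groups and a nitrile on this ring keep it level with the single chloro ring, a 1.7-fold higher number from compound 1 to compound 4 (0.22 log units; within the scatter), while a 2.0-fold higher number from compound 2 to compound 4 (0.31 log units; beyond the scatter), a small step that only just clears the scatter. No measurement at hand gives a reason for these shifts.

From the compounds shown here alone, the two chloro groups and the nitrile arrive together in one step, so how much of the result belongs to each stays open. Going by these compounds, how a ring carrying an amine or a carboxylic acid at this place would read in this assay also stays open.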